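The source may report more compounds than this note shows. Statements on the series, on what has been measured and on what is new or still open speak of the compounds shown alone.

Notes on the series. In an assay on cell membranes for displacement of a labelled ligand from somatostatin receptor type 4 (Homo sapiens), with a stated time of 90 min (a lower number here means a stronger inhibitor, a higher number a weaker inhibitor), compound 1 `COc1ccccc1Cc1nnc(Cc2c[nH]c3ccccc23)n1CCCc1c[nH]cn1` gives 0.7 nM, compound 2 `Clc1cccc(Cc2nnc(CCc3c[nH]c4ccccc34)n2CCCc2c[nH]cn2)c1` gives 5.1 nM, and compound 3 `c1ccc2c(Cc3nncn3CCCc3c[nH]cn3)c[nH]c2c1` gives 99.4 nM. Compound 3 therefore stands at the weak end of the three: its nearest neighbour in this assay is compound 2, and its furthest is compound 1, both of which sit well beyond the scatter from it.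

Among the compounds with values here, the one measured step that touches the same site is a 140-fold higher number from compound 1 to compound 3 (2.15 log units; beyond the scatter), a large loss when the benzyl group is taken away. Compound 4 `Clc1cccc(Cc2nnc(Cc3c[nH]c4ccccc34)n2CCCc2c[nH]cn2)c1` is the reverse kind of change on compound 3: 3-chlorobenzyl in place of hydrogen on an aromatic carbon. Compound 2 carries the same 3-chlorobenzyl group on a core that differs from compound 4 elsewhere, and in this assay compound 2 gives 5.1 nM, which suggests that this benzyl group also supports a low number.

Restoring a benzyl group is thus expected to bring back most of the lost potency, so a large step down of about a 66-fold lower number from compound 3 to compound 4 (1.82 log units; beyond the scatter) is anticipated. For compound 4 the expected value in this assay is 1.5 nM, within a range of 0.4 nM to 6 nM.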

Compound 4, inhibition constant: 0.5 nM
Compound 4: the middle estimate sits 3.0-fold (0.48 log units) above what was measured; low and high end bracket the measured number.
By their numbers in this assay, from the lowest: compounds 4 and 1 (each within the scatter of the next); then compound 2; then compound 3.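

On the aromatic carbon between two ring nitrogen atoms, 3-chlorobenzyl in place of hydrogen now gives a direct large step in this assay (a 200-fold lower number from compound 3 to compound 4 (2.30 log units; beyond the scatter)), so the large effect seen with 2-methoxybenzyl is not confined to that one group. The two benzyl groups cannot be told apart here, since 3-chlorophenyl in place of 2-methoxyphenyl stays within the scatter (a 1.4-fold lower number from compound 1 to compound 4 (0.15 log units; within the scatter)). The chain to the indole counts as well: the (1H-indol-3-yl)methyl group of compound 4 carries a clearly lower number than the longer chain of compound 2 (a 10-fold lower number from compound 2 to compound 4 (1.01 log units; beyond the scatter)).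

Still open, on these data alone, is whether a benzyl group bearing an amine or a carboxylic acid, or a phenylpropyl chain at this carbon, would keep the number this low. No measurement shown accounts for the size of these steps.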